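The compounds below may be only part of what the source reports. "The series", "measured", "known", "first", "only" and "open" are said of these compounds alone.

Measured in a functional assay on MDA-MB-231 cells (Homo sapiens) for antiproliferative activity, read by sulforhodamine B assay; a higher number here means a weaker inhibitor of growth, a lower number a stronger inhibitor of growth:

compound 1 `COc1ccc2sc(NC(=O)c3ccc(C)cc3)nc2c1` gives > 10 ug/mL, a limit of the assay.
compound 2 `COc1ccc(C(=O)Nc2nc3cc(OC)ccc3s2)cc1` gives > 10 ug/mL, a limit of the assay.

Compound 2 stands at the limit of this assay, and so does compound 1; both of the shown values sit there (the limit of > 10 ug/mL in this assay, at which 2 of the 2 values shown sit). Going by the values given here, the one measured step, a step that the two limits leave unreadable from compound 1 to compound 2, is therefore not readable in size or direction.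

Compound 3 `COc1ccc2sc(NC(=O)c3ccc([N+](=O)[O-])cc3)nc2c1` differs from compound 2 by nitro in place of methoxy on an aromatic carbon. Among the compounds with values here, no measured step touches a nitro group; the only step, methoxy in place of methyl, ends in two limits and gives no size to lean on. The expectation for compound 3 is thus anchored on the limit at which compound 2 stands, with wide uncertainty. The step that the limit leaves unreadable from compound 2 to compound 3 is expected to be small, within the scatter, or not readable. Compound 3 is estimated at 12 ug/mL in this assay, within 3 ug/mL to 40 ug/mL, with a fair chance that only a limit is reported again.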

Compound 3, concentration for 50% growth inhibition: > 10 ug/mL
Compound 3: no number, only a limit; the forecaster's own chance of this, stated with the estimate: 60%; the middle value is on the limit's open side.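

Compound 1, compound 2 and compound 3 all give only a limit in this assay, so no step among them can be read in size or direction: the limit of > 10 ug/mL in this assay, at which 3 of the 3 values shown sit.

The compounds shown leave open whether methyl, methoxy and nitro differ at all in their effect on growth inhibition.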